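Trading a Ring-Bearing Side Chain for a Small Amide Group

The source may hold more compounds than are shown below. What is called first, only, known or untested is meant among the compounds shown, and "the series" means these compounds.

Three measured compounds share one core and differ only in the group carried on a saturated chain carbon bound to a saturated ring carbon. Compound 1 `CCN1CCN(C[C@H]2CN(c3ccc(-n4cc(-c5ccccn5)cn4)c(F)c3)C(=O)O2)CC1` bears a 4-ethylpiperazin-1-yl group there; in a physicochemical assay for lipophilicity, read by HPLC, measured as octanol-water partition (on this read-out lower numbers stand for lower lipophilicity and higher numbers for higher lipophilicity), compound 1 gives 2.19, the highest of the three numbers. Compound 2 `O=C1CCC(=O)N1C[C@H]1CN(c2ccc(-n3cc(-c4ccccn4)cn3)c(F)c2)C(=O)O1` gives 1.58 in this assay, and the step of a number 0.61 log units lower from compound 1 to compound 2 (beyond the scatter) is beyond the scatter. Compound 3 `COC(=O)NC[C@H]1CN(c2ccc(-n3cc(-c4ccccn4)cn3)c(F)c2)C(=O)O1` gives 2.03, and the step of a number 0.16 log units lower from compound 1 to compound 3 (within the scatter) stays within the scatter, while the step of a number 0.45 log units higher from compound 2 to compound 3 (beyond the scatter) is again a modest one.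

Compound 4 `CNC(=O)[C@H]1CN(c2ccc(-n3cc(-c4ccccn4)cn3)c(F)c2)C(=O)O1` has not yet been measured. It differs from compound 1 by a larger change than the two measured ones: methylcarbamoyl in place of (4-ethylpiperazin-1-yl)methyl on a saturated ring carbon. The whole (4-ethylpiperazin-1-yl)methyl group, nine heavy atoms with a six-membered ring, is replaced by methylcarbamoyl, four heavy atoms with one hydrogen-bond donor. The measured steps that bear on this, a number 0.61 log units lower from compound 1 to compound 2 (beyond the scatter) and a number 0.16 log units lower from compound 1 to compound 3 (within the scatter), both point downward or flat, so a modest decrease in this assay is expected. The expected step is a number 0.64 log units lower from compound 1 to compound 4 (beyond the scatter). For compound 4 in this assay the estimated value is 1.55, with a range from 1.05 to 2.05.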

Compound 4, partition coefficient: 1.39
Beside the measured number, compound 4's estimate is 0.16 log units above it; measured number inside the range.
By their numbers in this assay, from the lowest: compounds 4 and 2 (each within the scatter of the next); then compounds 3 and 1 (each within the scatter of the next).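

In this assay the step of a number 0.80 log units lower from compound 1 to compound 4 (beyond the scatter) shows that exchanging the whole (4-ethylpiperazin-1-yl)methyl group for methylcarbamoyl on this saturated ring carbon moves the number beyond the scatter, which the exchange for the ((methoxycarbonyl)amino)methyl group of compound 3 did not do. The two ring-free groups do not read alike either: the step of a number 0.64 log units lower from compound 3 to compound 4 (beyond the scatter) also lies beyond the scatter. The step of a number 0.19 log units lower from compound 2 to compound 4 (within the scatter) stays within the scatter even though compound 2 keeps a ring in its (2,5-dioxopyrrolidin-1-yl)methyl group and compound 4 has none, so among these four compounds the presence of a ring in the group does not sort the numbers.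

The compounds shown leave open how a (methylcarbamoyl)methyl group, with a chain carbon before the amide, or a carboxylic acid on the same ring carbon would read, and so whether the chain carbon or the amide hydrogen counts for more in this change. Nothing available here gives a measured reason for any of these steps.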